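A few compounds are considered here, and "the series" means these few. Any claim that something is new, unique, unknown or untested is made for them only; others in the source may bear on it.

The shared core of this small set is seen in compound 1 `COc1cc2nc(SCC(=O)Nc3ccc([N+](=O)[O-])cc3)nc(Nc3c(C)cc(/C=C/C#N)cc3C)c2cc1OC`. In an ADME assay on MT4 cells (Homo sapiens) for cytotoxicity, read by MTT assay, with a stated time of 5 days (a higher number here means that more compound is tolerated, a lower number that less compound is tolerated), compound 1 gives only a limit rather than a number, > 219000 nM. Compound 2 `COc1cc2nc([S+]([O-])CC(=O)Nc3ccc(F)cc3)nc(Nc3c(C)cc(/C=C/C#N)cc3C)c2cc1OC` gives 27400 nM in this assay, a plain number. Compound 3 `COc1cc2nc([S+]([O-])CC(=O)Nc3ccccc3[N+](=O)[O-])nc(Nc3c(Cl)cc(/C=C/C#N)cc3Cl)c2cc1OC` gives in this assay only a limit, > 199000 nM. On the numbers shown, compound 3 therefore stands at the upper edge of what was measured: it sits at the limit of > 199000 nM in this assay, at which 1 of the 3 values shown sits, while another compound sits at the limit of > 219000 nM in this assay, at which 1 of the 3 values shown sits, and only one compound has a number below both.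

Compound 4 `COc1cc2nc([S+]([O-])CC(=O)Nc3cc([N+](=O)[O-])ccc3F)nc(Nc3c(Cl)cc(/C=C/C#N)cc3Cl)c2cc1OC` has not yet been measured. It differs from compound 3 in one place, (2-fluoro-5-nitrophenyl in place of 2-nitrophenyl on an amide-type nitrogen). Among the compounds with values here, no measured pair in this set differs in just one place, so no measured step of this kind is available to lean on. The step from compound 3 to compound 4 is expected to be an at least 1.1-fold lower number from compound 3 to compound 4 (0.04 log units; that floor lies within the scatter), that is, none beyond the usual scatter. In this assay compound 4 is estimated at about 180000 nM, within 60000 nM to 400000 nM, and the reading may again come back as a limit rather than a number.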

Compound 4, half-maximal cytotoxic concentration: > 194000 nM
Compound 4: only a limit was reported (the forecaster's own chance of this, stated with the estimate: 60%); middle value at least 1.0-fold (0.03 log units) from the limit.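

Compound 3 and compound 4 both give only a limit in this assay, not a plain number, so no step can be read between them. The compounds shown leave open whether 2-fluoro-5-nitrophenyl in place of 2-nitrophenyl changes how much compound is tolerated at all.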